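A few compounds are considered here, and "the series" means these few. Any claim that something is new, unique, unknown or untested is made for them only; others in the source may bear on it.

Of the compounds shown here, two built on a shared core have been measured in a functional assay on NCI-H460 cells (Homo sapiens) for inhibition, read by sulforhodamine B assay, with a stated time of 48 h; on this read-out higher numbers stand for weaker inhibition of growth and lower numbers for stronger inhibition of growth. Compound 1 `O=C1C=COC(/C=C/c2ccccc2)C1` gives 82.4 uM in this assay. Compound 2 `O=C1C=COC(/C=C/c2ccc(C(F)(F)F)cc2)C1` gives 95.6 uM in this assay, and the step of a 1.2-fold higher number from compound 1 to compound 2 (0.06 log units; within the scatter) is within the scatter, so compound 2 stands alongside compound 1 with nothing to separate the two numbers. Compound 3 `COc1ccc(/C=C/C2CC(=O)C=CO2)cc1` has not yet been measured. It differs from compound 2 by methoxy in place of trifluoromethyl on an aromatic carbon. Within the data shown here, only one measured step touches the same place on the ring, a 1.2-fold higher number from compound 1 to compound 2 (0.06 log units; within the scatter), and it stayed within the scatter; no measured step exchanges trifluoromethyl for methoxy, so the expectation rests on that single step. A change no larger than the scatter is therefore expected in this assay, with no direction favoured. Compound 3 is expected to give about 85 uM in this assay, between 40 uM and 180 uM. The implied step a 1.1-fold lower number from compound 2 to compound 3 (0.05 log units; within the scatter) is expected to stay within the scatter.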

Compound 3, concentration for growth inhibition (reported as GI): 149 uM
Beside the measured number, compound 3's estimate is 1.8-fold (0.24 log units) below it, and the stated range covers the measured number.
By their numbers in this assay, from the lowest: compounds 1, 2 and 3 (each within the scatter of the next).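

In this assay the exchange of trifluoromethyl for methoxy on this aromatic carbon gives a 1.6-fold higher number from compound 2 to compound 3 (0.19 log units; within the scatter) and the exchange of hydrogen for methoxy gives a 1.8-fold higher number from compound 1 to compound 3 (0.26 log units; within the scatter) at the same place. The position has now carried a second group, one that brings a hydrogen-bond acceptor where trifluoromethyl has none, and neither new step leaves the scatter. Across hydrogen, trifluoromethyl and methoxy, then, these numbers show no measurable effect of the group at this position on growth inhibition, though all three compounds sit at similarly weak values.

As far as these compounds go, whether an amine, a carboxylic acid or a longer chain such as ethoxy at this position would give a step beyond the scatter remains open. No measurement shown here explains why the numbers fall where they do.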